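A few compounds are considered here, and "the series" means these few. Any claim that something is new, unique, unknown or untested is made for them only; others in the source may bear on it.

In a functional assay on PC-3 cells (Homo sapiens) for inhibition, read by MTT assay, with a stated time of 72 h (on this read-out higher numbers stand for weaker inhibition and lower numbers for stronger inhibition), compound 1 `O=C(CSc1nc(Nc2ccccc2)c2ccccc2n1)Nc1ccc(F)c(Cl)c1` gives 15500 nM. Compound 2 `C=CC(=O)Nc1cccc(NC(=O)CSc2nc(Nc3cccc(F)c3)c3ccccc3n2)c1` stands lowest of the two numbers shown: in this assay compound 2 gives 5370 nM, and its only neighbour, compound 1, sits at a higher number by a margin beyond the usual scatter. Compound 3 `C=CC(=O)Nc1cccc(NC(=O)CSc2nc(Nc3ccc(C(F)(F)F)cc3)c3ccccc3n2)c1` differs from compound 2 in one place: 4-(trifluoromethyl)phenyl in place of 3-fluorophenyl on a nitrogen on an aromatic ring. Going by the values given here, no measured pair shows this change, so its effect is unknown from the data. The expected step of a 1.1-fold lower number from compound 2 to compound 3 (0.03 log units; within the scatter) is small, in no direction beyond the scatter. Compound 3 is therefore estimated to give about 5000 nM, with a range from 1500 nM to 16000 nM.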

Compound 3, half-maximal inhibitory concentration: 12500 nM
Compound 3: middle estimate off by 2.5-fold (0.40 log units), on the low side, and the stated range covers the measured number.
By their numbers in this assay, from the lowest: compound 2; then compounds 3 and 1 (each within the scatter of the next).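

In this assay the exchange of 3-fluorophenyl for 4-(trifluoromethyl)phenyl on a nitrogen on an aromatic ring gives a 2.3-fold higher number from compound 2 to compound 3 (0.37 log units; beyond the scatter) and so shows that inhibition in these cells responds to the group at this position. Here, the group with 10 heavy atoms goes with weaker inhibition than the group with 7, but this single pair changes the substituent and its place on the ring together. Nothing available explains this shift. The compounds shown leave open whether 3-(trifluoromethyl)phenyl would behave like 3-fluorophenyl or like 4-(trifluoromethyl)phenyl at this position. They also leave open the effect of 4-methoxyphenyl there.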